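Moving the halogen on the phenyl ring: compound 3 to compound 4

This account rests on a few compounds, and the source may have more. Where it says the series, first, only, none or still open, it means among the compounds named here.

Measured compounds:
- Compound 1, `OC(CCn1nc2c(Br)c(Br)c(Br)c(Br)c2n1)c1cccc(Br)c1`: in a functional assay on MCF7 cells (Homo sapiens) for antiproliferative activity, read by MTT assay, with a stated time of 24 h, tested at 12.5 uM (a lower number here means a stronger effect, a higher number a weaker effect of the compound at the concentration tested), compound 1 gives 81%
- Compound 2, `COc1cccc(C(O)CCn2nc3c(Br)c(Br)c(Br)c(Br)c3n2)c1`: compound 2 gives 121%
- Compound 3, `OC(CCn1nc2c(Br)c(Br)c(Br)c(Br)c2n1)c1cccc(Cl)c1`: compound 3 gives 97%

All three compounds share the same core and differ only in the group on the phenyl ring attached to the carbon that carries the hydroxyl. On the numbers shown, compound 3 stands second highest of the three: compound 1 is nearer to it, as the step of a number 16 percentage points higher from compound 1 to compound 3 (beyond the scatter) shows, while compound 2 is further away, as the step of a number 24 percentage points lower from compound 2 to compound 3 (beyond the scatter) shows. The third step, a number 40 percentage points higher from compound 1 to compound 2 (beyond the scatter), links compounds 1 and 2 directly.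

Compound 4, `OC(CCn1nc2c(Br)c(Br)c(Br)c(Br)c2n1)c1ccc(Br)cc1`, has not yet been measured. Its change from compound 3 is 4-bromophenyl in place of 3-chlorophenyl on a saturated chain carbon bound to an oxygen on a saturated carbon and a saturated chain carbon. Two things happen at once: the chlorine becomes bromine again, and the halogen sits at a different position on the ring. Among the measured compounds shown here, the only measured step that bears on this is the chlorine-for-bromine exchange, a number 16 percentage points higher from compound 1 to compound 3 (beyond the scatter), a modest rise; reversing it would suggest a modest fall in this assay. Nothing measured speaks to the shift in position, so the expectation is held loosely.

Compound 4 is therefore expected to give about 86%, within 62% to 112%, which would mean an estimated step of a number 11 percentage points lower from compound 3 to compound 4 (beyond the scatter).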

Compound 4, a percentage reported as activity, at one concentration (the size of the read-out at that concentration, not a potency): 82%
For compound 4 the middle estimate is 4 percentage points above the measured one, and the stated range covers the measured number.
By their numbers in this assay, from the lowest: compounds 1 and 4 (each within the scatter of the next); then compound 3; then compound 2.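

In this assay, among the compounds shown here, the new result separates where the bromine sits from whether it is there: with a number 1 percentage points higher from compound 1 to compound 4 (within the scatter) there is no telling 4-bromophenyl and 3-bromophenyl apart, something no earlier compound could show. Set against 3-chlorophenyl, the step of a number 15 percentage points lower from compound 3 to compound 4 (beyond the scatter) is close in size to a number 16 percentage points higher from compound 1 to compound 3 (beyond the scatter) but runs the opposite way, and set against 3-methoxyphenyl, the step of a number 39 percentage points lower from compound 2 to compound 4 (beyond the scatter) is close in size to a number 40 percentage points higher from compound 1 to compound 2 (beyond the scatter) and likewise runs the opposite way. Across these four compounds the two bromine compounds therefore share the low end with no compound going against that, yet nothing measured here gives a reason for it.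

The compounds shown leave open whether 4-chlorophenyl or 4-methoxyphenyl would match their 3-substituted partners as closely as the two bromine groups match each other. Also open, going by these compounds, is what an amine or a carboxylic acid on the phenyl ring would do, or a longer chain in place of the one joining the hydroxyl-bearing carbon to the shared core.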